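Replacing the 1-methylpiperidin-4-yl Group of Compound 3

The source may report more compounds than this note shows. Statements on the series, on what has been measured and on what is new or still open speak of the compounds shown alone.

In an ADME assay on Caco-2 cells (Homo sapiens) for permeability, read by LC-MS, in the apical to basolateral direction, with a stated time of 90 min (a lower number here means that the compound crosses the layer more slowly, a higher number that the compound crosses the layer faster), compound 1 (`COc1ncc(-c2cc(OCC3CCOCC3)c3ncnc(C)c3c2)cc1NS(=O)(=O)c1ccc(F)cc1F`) gives 31 10^-6 cm/s and compound 2 (`COc1ncc(-c2cc(OC3CCOC(C)(C)C3)c3ncnc(C)c3c2)cc1NS(=O)(=O)c1ccc(F)cc1F`) gives 31 10^-6 cm/s. Compound 3 (`COc1ncc(-c2cc(OC3CCN(C)CC3)c3ncnc(C)c3c2)cc1NS(=O)(=O)c1ccc(F)cc1F`) gives 4.5 10^-6 cm/s, the lowest of the three numbers. Compound 4 (`COc1ncc(-c2cc(OC(C)C)c3ncnc(C)c3c2)cc1NS(=O)(=O)c1ccc(F)cc1F`) has not yet been measured. It departs from compound 3 at a single place, on an oxygen on an aromatic ring: isopropyl in place of 1-methylpiperidin-4-yl on an oxygen on an aromatic ring. Going by the values given here, three measured steps bear on this change. The values show no change at the digits printed from compound 1 to compound 2 (within the scatter), which lies within the scatter. By contrast, a 6.9-fold lower number from compound 1 to compound 3 (0.84 log units; beyond the scatter) and a 6.9-fold lower number from compound 2 to compound 3 (0.84 log units; beyond the scatter) are both modest but beyond the scatter. Among these three compounds, only compound 3 carries the 1-methylpiperidin-4-yl group, and no compound with an isopropyl group has a measured value yet. On the strength of these steps, removing that group is expected to restore a number of similar size in this assay. The expected change, upward and beyond the scatter, is a 6.7-fold higher number from compound 3 to compound 4 (0.82 log units; beyond the scatter). For compound 4 the estimated value is 30 10^-6 cm/s, with an expected range from 14 10^-6 cm/s to 50 10^-6 cm/s.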

Compound 4, apparent permeability: 32 10^-6 cm/s
Compound 4: the middle estimate sits 1.1-fold (0.03 log units) below what was measured; the measured number falls inside the stated range.
By their numbers in this assay, from the lowest: compound 3; then compounds 1, 2 and 4 (each within the scatter of the next).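

In this assay, the change to isopropyl gives a 7.1-fold higher number from compound 3 to compound 4 (0.85 log units; beyond the scatter), whereas a 1.0-fold higher number from compound 2 to compound 4 (0.01 log units; within the scatter) and a 1.0-fold higher number from compound 1 to compound 4 (0.01 log units; within the scatter) both remain within the scatter. At this position on the oxygen, a group with no ring therefore matches the two groups that contain an oxane ring, so neither that ring nor its oxygen is required to reach this level, and among the four compounds only compound 3, with its 1-methylpiperidin-4-yl group, stands apart. Nothing at hand gives a reason for this result.

The compounds shown cannot separate the part played by the ring nitrogen from that of the methyl on it or the piperidine ring as a whole. They also leave open how an unsubstituted piperidin-4-yl group, an open-chain amine such as 2-(dimethylamino)ethyl or a carboxylic acid would read here.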